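This account rests on a few compounds, and the source may have more. Where it says the series, first, only, none or still open, it means among the compounds named here.

Compound 1 `COc1ccc(N(C)c2ccnc(Cl)n2)cc1` is the parent of this small set. Among the measured compounds shown here, in a functional assay on HCT-116 cells (Homo sapiens) for antiproliferative activity, read by MTT assay, with a stated time of 48 h (a higher number here means a weaker inhibitor, a lower number a stronger inhibitor), compound 1 gives 1460 nM, the second highest of the three numbers measured so far. Compound 2 `COc1ccc(N(C)c2ccnc(Cl)n2)cc1[N+](=O)[O-]` gives 4700 nM in this assay, and compound 3 `COc1ccc(N(C)c2ccnc(Cl)n2)cc1O` gives 422 nM. The two steps away from the parent are a 3.2-fold higher number from compound 1 to compound 2 (0.51 log units; beyond the scatter) and a 3.5-fold lower number from compound 1 to compound 3 (0.54 log units; beyond the scatter); between the two substituted compounds the step is an 11-fold lower number from compound 2 to compound 3 (1.05 log units; beyond the scatter).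

Compound 4 `COc1ccc(N(C)c2ccnc(Cl)n2)cc1OCCCCBr` carries 4-bromobutoxy in place of hydrogen on an aromatic carbon. Both measured steps from compound 1 bear on it, since each puts a group on the same aromatic carbon, and both were modest but in opposite directions: nitro raised the number, hydroxy lowered it. For the measured compounds named here, no measured step covers a chain of this length on that carbon, so the direction is not settled by the data; an oxygen-linked group, as in compound 3, is the nearest precedent. A step no larger than modest is expected, a 1.5-fold lower number from compound 1 to compound 4 (0.16 log units; within the scatter), with a wide range on either side. For compound 4 the estimate is 1000 nM, between 300 nM and 4000 nM.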

Compound 4, half-maximal inhibitory concentration: 1140 nM
Compound 4: middle estimate off by 1.1-fold (0.06 log units), on the low side, and the stated range covers the measured number.
By their numbers in this assay, from the lowest: compound 3; then compounds 4 and 1 (each within the scatter of the next); then compound 2.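

In this assay the 4-bromobutoxy group on this aromatic carbon gives a 1.3-fold lower number from compound 1 to compound 4 (0.11 log units; within the scatter) and so shows that a chain of this length can stand there with no readable change from the parent. An oxygen on this carbon is not enough to hold the lower number of compound 3: 4-bromobutyl on the hydroxy oxygen gives a 2.7-fold higher number from compound 3 to compound 4 (0.43 log units; beyond the scatter) and the comparison with the nitro compound gives a 4.1-fold lower number from compound 2 to compound 4 (0.62 log units; beyond the scatter) so the chain-bearing compound lies apart from both. No measurement here accounts for these steps.

Going by these compounds, whether a shorter or longer chain on this oxygen, or a chain ending in an amine or a carboxylic acid instead of bromine, would move the number beyond the scatter stays open. On these data alone, the part played by the bromine itself also stays open, and a plain butoxy group would separate it from the chain.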